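This account rests on a few compounds, and the source may have more. Where it says the series, first, only, none or still open, it means among the compounds named here.

Measured compounds:
- compound 1, `O=C(CN1CCN(c2ccccc2Cl)CC1)N1CCN(c2nnc(-c3ccccc3)c(-c3ccccc3)n2)CC1`, which in an ADME assay on NIH3T3 cells (Mus musculus) for cytotoxicity, read by MTT assay, with a stated time of 24 h (a higher number here means a weaker inhibitor, a lower number a stronger inhibitor), gives 350000 nM
- compound 2, `O=C(CN1CCN(c2cccc(Cl)c2)CC1)N1CCN(c2nnc(-c3ccccc3)c(-c3ccccc3)n2)CC1`, for which compound 2 gives 178000 nM
- compound 3, `Cc1ccc(-c2nnc(N3CCN(C(=O)CN4CCN(c5ccccc5)CC4)CC3)nc2-c2ccc(C)cc2)cc1`, for which the assay reports only a limit: compound 3 gives > 914000 nM

Compound 3 thus stands apart from the other two in that no number is known for it, only (the limit of > 914000 nM in this assay, at which 1 of the 3 values shown sits). Within the data shown here, compound 1 and compound 2 share the same core as compound 3 and differ from each other only in the chlorophenyl on the amine nitrogen in a ring; that change gave a 2.0-fold lower number from compound 1 to compound 2 (0.29 log units; within the scatter), so the one measured step in this set is within the scatter.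

Compound 4, `COc1ccc(N2CCN(CC(=O)N3CCN(c4nnc(-c5ccc(C)cc5)c(-c5ccc(C)cc5)n4)CC3)CC2)cc1`, differs from compound 3 by methoxy in place of hydrogen on an aromatic carbon. Among the measured compounds shown here, no measured step touches this part of the molecule, so the step from compound 1 to compound 2 bears on it only indirectly, as a sign that small changes at the edges of the shared core did not move the numbers beyond the scatter. Compound 4 is therefore expected to sit near where compound 3 sits, with a step of an at least 1.0-fold lower number from compound 3 to compound 4 (0.00 log units; that floor lies within the scatter), which is no step beyond the scatter. For compound 4 the estimate is 900000 nM, between 300000 nM and 2000000 nM, and a limit rather than a number is thought likely.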

Compound 4, half-maximal inhibitory concentration: 116000 nM
Compound 4: the middle estimate sits 7.8-fold (0.89 log units) above what was measured, and the stated range ends above it.
By their numbers in this assay, from the lowest: compounds 4, 2 and 1 (each within the scatter of the next, the first and the last beyond it). At a limit, above all of these: compound 3.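

In this assay, the change from phenyl to 4-methoxyphenyl, with the methoxy para to a large group, gives an at least 7.8-fold lower number from compound 3 to compound 4 (0.89 log units; beyond the scatter). Among these compounds, this is the first step in the set that lies beyond the scatter, since the only earlier step, a 2.0-fold lower number from compound 1 to compound 2 (0.29 log units; within the scatter), swapped 2-chlorophenyl for 3-chlorophenyl on the same amine nitrogen and stayed within it, so the aromatic ring on that nitrogen can respond to a single substituent. From the compounds shown here alone, the size of the new step is only a floor, and its upper end stays unknown, since compound 3 is held at a limit and not at a number: the limit of > 914000 nM in this assay, at which 1 of the 4 values shown sits.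

The compounds shown leave open whether the lower number is particular to methoxy or would also appear with another group at the same place, such as a hydroxyl, a fluorine, an amine or a longer chain like ethoxy. They also leave open whether methoxy would produce a step of similar size on the core of compound 1, which carries no methyl groups, and a measured number for compound 3 would be needed to fix the size of the step itself.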